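The source may hold more compounds than are shown below. What is called first, only, known or untested is meant among the compounds shown, and "the series" means these compounds.

Compound 1, `O=C(CSc1nnnn1-c1ccccc1)N/N=c1/scc(-c2ccc(Br)cc2)n1-c1ccccc1`, sits lowest of the three numbers in a functional assay on C6 cells (Rattus norvegicus) for cytotoxicity, read by MTT assay, with a stated time of 24 h, tested at 50 ug/mL (on this read-out lower numbers stand for a stronger effect and higher numbers for a weaker effect at the one concentration tested), at 32%. Compound 2, `O=C(CSc1ncccn1)N/N=c1/scc(-c2ccc(Br)cc2)n1-c1ccccc1`, gives 69%, and compound 3, `Cn1cnnc1SCC(=O)N/N=c1/scc(-c2ccc(C#N)cc2)n1-c1ccccc1`, gives 58.8%. Going by the values given here, the one step measured in one place, a number 37 percentage points higher from compound 1 to compound 2 (beyond the scatter), changes the group on the sulfur, not the aryl ring, and so does not bear on the change now considered. Compound 4, `O=C(CSc1nnnn1-c1ccccc1)N/N=c1/scc(-c2ccccc2)n1-c1ccccc1`, differs from compound 1 by hydrogen in place of bromo on an aromatic carbon, on an aromatic carbon of a six-membered aromatic ring of carbon only. Among the compounds with values here, with no measured step touching that ring, compound 4 is expected to show a modest weakening, a number 13 percentage points higher from compound 1 to compound 4 (beyond the scatter), that may not exceed the scatter. Compound 4 is therefore estimated at 45%, between 25% and 70%.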

Compound 4, a percentage reported as activity, at one concentration (the size of the read-out at that concentration, not a potency): 36.7%
Compound 4: the middle estimate sits 8.3 percentage points above what was measured, and the stated range covers the measured number.
By their numbers in this assay, from the lowest: compounds 1 and 4 (each within the scatter of the next); then compound 3; then compound 2.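

In this assay, hydrogen in place of bromo gives a number 4.7 percentage points higher from compound 1 to compound 4 (within the scatter) with the 1-phenyl-1H-tetrazol-5-yl group kept on the sulfur. Going by these compounds alone, this is the first reading at this position, and it shows that, in this pair, the 4-bromophenyl to phenyl change leaves the number within the scatter. The bromo is therefore not required for the effect seen with compound 1 at the one concentration tested.

From the compounds shown here alone, whether this holds with pyrimidin-2-yl on the sulfur remains open, as does the effect of a methoxy group or an amine at this position. No available evidence accounts for this result.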